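From a Pyridyl to a Chlorophenylethenyl Arm: Compound 4

The source may hold more compounds than are shown below. What is called first, only, known or untested is meant among the compounds shown, and "the series" means these compounds.

Compound 1 `Cc1csc(N)c1C(=O)c1ccc(Cl)cc1`, compound 2 `Cc1c(-c2ccccc2)sc(N)c1C(=O)c1ccc(Cl)cc1` and compound 3 `CC(C)(C)Cc1c(-c2cccnc2)sc(N)c1C(=O)c1ccc(Cl)cc1` share one core. In an assay on CHO cells for displacement of a labelled ligand from adenosine receptor A3 (Homo sapiens), read by scintillation counting, tested at 10 uM (on this read-out higher numbers stand for more inhibition at the one concentration tested (going by the name of the read-out) and lower numbers for less inhibition), compound 1 gives 1%, compound 2 gives 1% and compound 3 gives 1%; compound 3 thus stands level with the other two within the scatter. Going by the values given here, the only single-point step measured, no change at the digits printed from compound 1 to compound 2 (within the scatter), came with phenyl in place of hydrogen on an aromatic carbon. Compound 4 `CC(C)(C)Cc1c(/C=C/c2ccc(Cl)cc2)sc(N)c1C(=O)c1ccc(Cl)cc1` differs from compound 3 by 2-(4-chlorophenyl)ethenyl in place of pyridin-3-yl on an aromatic carbon. Among the compounds with values here, no measured step covers this exact exchange; the one step on an aromatic carbon of the shared core was flat, and all three measured values sit at the low end of the scale, so the expected step of a number 2 percentage points higher from compound 3 to compound 4 (within the scatter) is none beyond the scatter. Compound 4 is therefore expected to give 3%, between -8% and 20%.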

Compound 4, a percentage reported as inhibition, at one concentration (the size of the read-out at that concentration, not a potency): 11%
The estimate for compound 4 lay 8 percentage points below the measured number; the measured number falls inside the stated range.
By their numbers in this assay, from the lowest: compounds 1, 2, 3 and 4 (each within the scatter of the next).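

In this assay, 2-(4-chlorophenyl)ethenyl in place of pyridin-3-yl, on the aromatic carbon next to the ring sulfur, gives a number 10 percentage points higher from compound 3 to compound 4 (within the scatter). This position therefore accepts an arm with a double bond and a chlorine-bearing carbon ring in place of the pyridine ring, with no change beyond the scatter. Nothing available explains the result.

From the compounds shown here alone, whether the chlorine on the arm matters remains open. So does whether an amine or a carboxylic acid on this arm would move the read-out beyond the scatter.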